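Terminal amide chain variation on a spiro hydantoin scaffold

The source may hold more compounds than are shown below. What is called first, only, known or untested is meant among the compounds shown, and "the series" means these compounds.

Measured compounds:
Compound 1 `CC(C)(C)OC(=O)NCCNC(=O)CN1CN(c2ccccc2)C2(CCN(C(=O)c3ccc(C4CCCCC4)cc3)CC2)C1=O` — 5500 nM
Compound 2 `CC(C)(C)OC(=O)NCCCCNC(=O)CN1CN(c2ccccc2)C2(CCN(C(=O)c3ccc(C4CCCCC4)cc3)CC2)C1=O` — 4600 nM
Compound 3 `CS(=O)(=O)NCCNC(=O)CN1CN(c2ccccc2)C2(CCN(C(=O)c3ccc(C4CCCCC4)cc3)CC2)C1=O` — 2100 nM

In an assay on HEK293 cells for displacement of a labelled ligand from NPC1-like intracellular cholesterol transporter 1 (Homo sapiens) (a higher number here means a weaker inhibitor, a lower number a stronger inhibitor), compound 3 stands lowest of the three numbers. Its nearest neighbour is compound 2, and the change from that compound is a 2.2-fold lower number from compound 2 to compound 3 (0.34 log units; beyond the scatter). The step of a 2.6-fold lower number from compound 1 to compound 3 (0.42 log units; beyond the scatter) is of similar size, while the step of a 1.2-fold lower number from compound 1 to compound 2 (0.08 log units; within the scatter) shows that lengthening the chain alone made no difference beyond the scatter.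

Compound 4 `COC(=O)CCNC(=O)CN1CN(c2ccccc2)C2(CCN(C(=O)c3ccc(C4CCCCC4)cc3)CC2)C1=O` is not yet measured. It differs from compound 3 by methoxycarbonyl in place of methanesulfonamido on a saturated chain carbon, two bonds along the chain from an amide-type nitrogen. For the measured compounds named here, no measured step of this kind exists here; the two steps that end at compound 3 both exchange a tert-butoxycarbonyl group for a methylsulfonyl one, and both were modest. Because the gains seen in a 2.6-fold lower number from compound 1 to compound 3 (0.42 log units; beyond the scatter) and a 2.2-fold lower number from compound 2 to compound 3 (0.34 log units; beyond the scatter) were small, the expectation for compound 4 is a number not far from that of compound 3, with a modest rise more likely than a further fall. For compound 4 the expected step is a 1.7-fold higher number from compound 3 to compound 4 (0.22 log units; within the scatter). Compound 4 is estimated at 3500 nM, within a range from 1500 nM to 8000 nM.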

Compound 4, half-maximal inhibitory concentration: 12900 nM
Estimate against measurement, compound 4: 3.7-fold (0.57 log units) below, and the stated range ends below it.
By their numbers in this assay, from the lowest: compound 3; then compounds 2 and 1 (each within the scatter of the next); then compound 4.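

In this assay, methoxycarbonyl in place of methanesulfonamido on a saturated chain carbon, two bonds along the chain from an amide-type nitrogen, gives a 6.1-fold higher number from compound 3 to compound 4 (0.79 log units; beyond the scatter) as the largest step in the set, so this position responds to a change of end group in the upward direction as well as the downward one seen before. The same end group also stands apart from both tert-butoxycarbonyl compounds, with a 2.8-fold higher number from compound 2 to compound 4 (0.45 log units; beyond the scatter) and a 2.3-fold higher number from compound 1 to compound 4 (0.37 log units; beyond the scatter), so the loss does not depend on comparison with the methanesulfonamido compound alone. The change removes the single hydrogen-bond donor of the group and keeps the count of acceptors, but it also exchanges nitrogen and sulfur for carbon and oxygen, and nothing here gives a reason for the loss or separates these differences.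

The compounds shown leave open whether restoring a nitrogen-hydrogen alone, as in an N-methyl amide at the chain end, would recover the lost ground. They also leave open how a carboxylic acid or a primary amine at this place would compare, and whether a longer chain ending in methanesulfonamido would keep the number of compound 3.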